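Benzyl in place of methyl on the amide nitrogen

This account rests on a few compounds, and the source may have more. Where it says the series, first, only, none or still open, it means among the compounds named here.

Compound 1 `CN1C(=O)C2(C(C#N)=C(N)Oc3cc4oc(-c5ccccc5)cc(=O)c4c(O)c32)c2cc(Cl)ccc21` is the chloro member of the series. In a functional assay on NCI-H1299 cells (Homo sapiens) for antiproliferative activity, read by MTT assay, with a stated time of 48 h (on this read-out lower numbers stand for stronger inhibition and higher numbers for weaker inhibition), compound 1 gives 11200 nM, which is the highest of the two numbers shown; the nearest value belongs to compound 2 `CN1C(=O)C2(C(C#N)=C(N)Oc3cc4oc(-c5ccccc5)cc(=O)c4c(O)c32)c2cc(Br)ccc21`, for which this assay gives 7610 nM. Within the data shown here, the one measured step, a 1.5-fold lower number from compound 1 to compound 2 (0.17 log units; within the scatter), is the only single-point comparison available. Compound 3 `Cc1cccc2c1N(Cc1ccccc1)C(=O)C21C(C#N)=C(N)Oc2cc3oc(-c4ccccc4)cc(=O)c3c(O)c21` carries a benzyl on the amide nitrogen together with a methyl on the aromatic ring. Among the measured compounds shown here, for compound 3 this assay reports only a limit, > 50000 nM, as noted in the limit of > 50000 nM in this assay, at which 1 of the 3 values shown sits; compound 3 differs from compound 1 in more than one place, so no step can be counted from it.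

Compound 4 `N#CC1=C(N)Oc2cc3oc(-c4ccccc4)cc(=O)c3c(O)c2C12C(=O)N(Cc1ccccc1)c1ccc(Cl)cc12` keeps the chloro of compound 1 and changes only the substituent on the amide nitrogen: phenyl in place of hydrogen on a saturated chain carbon bound to an amide-type nitrogen in a ring. For the measured compounds named here, no measured step covers this change. The halogen swap says nothing about it, and the limit for compound 3 confounds the benzyl with a second change. The expectation for compound 4 is therefore a weakening, a 2.0-fold higher number from compound 1 to compound 4 (0.29 log units; within the scatter), with wide uncertainty. Compound 4 is estimated at 22000 nM, between 7000 nM and 60000 nM.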

Compound 4, half-maximal inhibitory concentration: > 50000 nM
Compound 4: a limit, no number; the forecaster's own chance of this, stated with the estimate: 25%; middle value at least 2.2-fold (0.35 log units) from the limit.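

Methyl to benzyl on the amide nitrogen, with the chloro of compound 1 held fixed, is now a single change with a readable outcome in this assay: an at least 4.4-fold higher number from compound 1 to compound 4 (0.64 log units; beyond the scatter). Among these compounds, this separates the benzyl from the second change carried by compound 3, so in the chloro series this nitrogen substituent alone moves the read-out beyond the scatter, whereas the only earlier step, a 1.5-fold lower number from compound 1 to compound 2 (0.17 log units; within the scatter), stayed within it. The reading for compound 4 is a limit and not a number: the limit of > 50000 nM in this assay, at which 2 of the 4 values shown sit.

The step therefore fixes a direction and a minimum size, and how far the number rises beyond that stays unread, as does whether the same change on the bromo compound 2 would behave alike. Also open, from the compounds shown here alone, is where along the substituent the weakening sets in: an ethyl or a longer chain on the amide nitrogen, a benzyl replaced by a chain ending in an amine or a carboxylic acid, or the bare amide hydrogen would show whether any group other than methyl holds the number of compound 1.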